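This account rests on a few compounds, and the source may have more. Where it says the series, first, only, none or still open, it means among the compounds named here.

Series notes. Compound 1 `Oc1nc2nonc2nc1Nc1ccc(SC(F)(F)F)cc1` gives 1400 nM in an assay on mitochondria from L6 cells (Rattus norvegicus) for activation, with a stated time of 90 min (a lower number here means that less compound is needed, a higher number that more compound is needed for the effect), the lowest of the three numbers in hand. Compound 2 `Cc1cc(OC(F)(F)F)ccc1Nc1nc2nonc2nc1O` gives 4600 nM in this assay, and compound 3 `Oc1nc2nonc2nc1NCc1ccc(OC(F)(F)F)cc1` gives 13400 nM; both sit above compound 1 by more than the scatter. Compound 4 `Oc1nc2nonc2nc1Nc1ccc(Cl)cc1` has not yet been measured. It differs from compound 1 in one place: chloro in place of (trifluoromethyl)sulfanyl on an aromatic carbon. Going by the values given here, no measured pair shows this exchange, so its effect cannot be read off directly from the data in hand. The step expected is a 2.1-fold higher number from compound 1 to compound 4 (0.33 log units; beyond the scatter), a modest rise in the number, with a real chance of no change beyond the scatter. Compound 4 is accordingly estimated at 3000 nM, within 1000 nM to 9000 nM.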

Compound 4, half-maximal effective concentration: 11700 nM
Compound 4: middle estimate off by 3.9-fold (0.59 log units), on the low side, outside the stated range (above it).
By their numbers in this assay, from the lowest: compound 1; then compound 2; then compounds 4 and 3 (each within the scatter of the next).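

In this assay, going by these compounds alone, the exchange of (trifluoromethyl)sulfanyl for chloro on this aromatic carbon gives an 8.4-fold higher number from compound 1 to compound 4 (0.92 log units; beyond the scatter) and forms the first single-place step. The number therefore responds to the group at this position, and chloro does not stand in for (trifluoromethyl)sulfanyl here. No measured property accounts for the size of this step. From the compounds shown here alone, it remains open which part of the (trifluoromethyl)sulfanyl group the number depends on. A trifluoromethyl, a methylsulfanyl or a nitrile on this carbon would help separate these parts.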